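The source may hold more compounds than are shown below. What is called first, only, known or untested is meant among the compounds shown, and "the series" means these compounds.

Measured so far in an ADME assay on MCF-10A cells (Homo sapiens) for cytotoxicity, read by sulforhodamine B assay, with a stated time of 48 h; a higher number here means a weaker inhibitor of growth, a lower number a stronger inhibitor of growth:
compound 1 `O=C1C(=O)N(CN2CCN(c3ccnc4cc(Cl)ccc34)CC2)c2cccc(Br)c21`, 65600 nM
compound 2 `O=C1C(=O)N(CN2CCN(c3ccnc4cc(Cl)ccc34)CC2)c2ccccc21`, 45900 nM
compound 3 `NC(=S)N/N=C1/C(=O)N(CN2CCN(c3ccnc4cc(C(F)(F)F)ccc34)CC2)c2cc(Br)ccc21`, 27000 nM

For the measured compounds named here, the one counted step, (hydrogen in place of bromo on an aromatic carbon), gave a 1.4-fold lower number from compound 1 to compound 2 (0.16 log units; within the scatter). Compound 3 has a different core; the difference between the core of compound 3 and the core of compound 1 is not broken down here. Compound 4 `NC(=S)N/N=C1/C(=O)N(CN2CCN(c3ccnc4cc(C(F)(F)F)ccc34)CC2)c2ccccc21` is not yet measured and differs from compound 3 by hydrogen in place of bromo on an aromatic carbon. This is the same kind of change as that between compound 1 and compound 2, not the same: the place is ortho to a fused ring and meta to a fused ring in compound 1, but meta to a fused ring and para to a fused ring in compound 3. A step of a 1.2-fold lower number from compound 3 to compound 4 (0.09 log units; within the scatter) is expected in this assay, resting on a 1.4-fold lower number from compound 1 to compound 2 (0.16 log units; within the scatter). Compound 4 is therefore estimated at 22000 nM, with a range from 9000 nM to 60000 nM.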

Compound 4, concentration for 50% growth inhibition: 22600 nM
The estimate for compound 4 lay 1.0-fold (0.01 log units) below the measured number; the range from low to high includes it.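

In this assay hydrogen in place of bromo on an aromatic carbon gives a 1.2-fold lower number from compound 3 to compound 4 (0.08 log units; within the scatter) and stands close to the earlier step on the other core: the same change on two cores in this assay, a 1.4-fold lower number (0.16 log units; within the scatter) from compound 1 to compound 2 and a 1.2-fold lower number (0.08 log units; within the scatter) from compound 3 to compound 4, 1.2-fold (0.08 log units) apart, within the scatter of two such steps

The change thus carries between these two cores with no difference that can be read in this assay. For the compounds shown here, it does not show a general rule: only two cores are compared, the bromo sits at a different place on each, and neither step lies beyond the scatter, so a small effect cannot be told from none.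

Open, as far as these compounds go, is whether a group other than bromo or hydrogen on that aromatic carbon, such as a methoxy group, an amine or a carboxylic acid, gives a step beyond the scatter. Also open, from the compounds shown here alone, is how the same change reads in a core carrying a longer chain on the ring nitrogen.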